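Cytotoxicity notes on the side-chain variants of compound 3

A few compounds are considered here, and "the series" means these few. Any claim that something is new, unique, unknown or untested is made for them only; others in the source may bear on it.

Compound 3 `CCCCCc1ccc(-c2cc3cn([C@H]4C[C@H](O)[C@@H](COC(=O)[C@@H](NC(=O)[C@@H]5CCCN5C(=O)[C@@H](N)CCCCN)C(C)C)O4)c(=O)nc3o2)cc1` carries a 4-aminobutyl side chain on the terminal amino acid of its ester. In an ADME assay on HEL cells (Homo sapiens) for cytotoxicity (on this read-out higher numbers stand for lower toxicity in this test and lower numbers for higher toxicity in this test), compound 3 gives > 5000 nM, which is a limit of the assay and not a number. Compound 1 `CCCCCc1ccc(-c2cc3cn([C@H]4C[C@H](O)[C@@H](COC(=O)[C@@H](NC(=O)[C@@H]5CCCN5C(=O)[C@@H](N)C(C)C)C(C)C)O4)c(=O)nc3o2)cc1`, the isopropyl analogue, gives in this assay a value of > 2000 nM, likewise a limit. Compound 2 `CCCCCc1ccc(-c2cc3cn([C@H]4C[C@H](O)[C@@H](COC(=O)[C@@H](NC(=O)[C@@H]5CCCN5C(=O)[C@@H](N)CC(N)=O)C(C)C)O4)c(=O)nc3o2)cc1`, with carbamoylmethyl at the same position, gives in this assay > 5000 nM, again a limit. The steps a step that the two limits leave unreadable from compound 1 to compound 2, a step that the two limits leave unreadable from compound 1 to compound 3 and a step that the two limits leave unreadable from compound 2 to compound 3 therefore have no readable size; the limit of > 2000 nM in this assay, at which 1 of the 3 values shown sits, and the limit of > 5000 nM in this assay, at which 2 of the 3 values shown sit, mark where the three values sit. Compound 3 thus stands at one of the two limits, alongside compound 2, without any readable order among the three.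

Compound 4 `CCCCCc1ccc(-c2cc3cn([C@H]4C[C@H](O)[C@@H](COC(=O)[C@@H](NC(=O)[C@@H]5CCCN5C(=O)[C@@H](N)CC(=O)O)C(C)C)O4)c(=O)nc3o2)cc1` differs from compound 3 by carboxy in place of 3-aminopropyl on a saturated chain carbon, two bonds along the chain from an amine nitrogen and a carbonyl carbon. For the measured compounds named here, the steps that bear on this position, a step that the two limits leave unreadable from compound 1 to compound 3 and a step that the two limits leave unreadable from compound 2 to compound 3, give no readable size, so no step beyond the scatter in either direction can be expected in this assay. Compound 4 is expected at 5000 nM with a range from 2000 nM to 12000 nM, which means an expected step of a number no higher from compound 3 to compound 4 (the limit leaves the size open). The assay will most probably report a limit again.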

Compound 4, minimum cytotoxic concentration: > 5000 nM
Compound 4 was reported as a limit (the forecaster's own chance of this, stated with the estimate: 85%); the middle value sits exactly at the limit.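

In this assay compound 4 gives > 5000 nM, a limit of the assay and not a number. For the compounds shown here, its steps from compound 1, compound 2 and compound 3 cannot be read, so this result adds no new step. The compounds shown leave open whether these four side chains differ at all in this assay, with all four values standing as limits.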